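This account rests on a few compounds, and the source may have more. Where it says the series, first, only, none or still open, it means among the compounds named here.

Working notes on the anilino series sharing the core of compound 1 `Cc1n[nH]c2ccc(-c3nc4cnc(N5CCN(C)CC5)cn4c3Nc3ccc(Br)cc3)cc12`.

Compound 1 stands highest of the three numbers in a functional assay on MV4-11 cells (Homo sapiens) for inhibition, with a stated time of 120 h, tested at 10 uM (on this read-out higher numbers stand for more inhibition at the one concentration tested (going by the name of the read-out) and lower numbers for less inhibition), giving 83%. Compound 3 `Cc1n[nH]c2ccc(-c3nc4cnc(N5CCN(C)CC5)cn4c3Nc3ccc(Cl)cc3Cl)cc12` gives 78.8% in this assay, and the step of a number 4.2 percentage points lower from compound 1 to compound 3 (within the scatter). Compound 2 `COc1ccc(Nc2c(-c3ccc4[nH]nc(C)c4c3)nc3cnc(N4CCN(C)CC4)cn23)cc1OC` gives 6.27%, and the step of a number 76.7 percentage points lower from compound 1 to compound 2 (beyond the scatter); the step of a number 72.5 percentage points higher from compound 2 to compound 3 (beyond the scatter) points the same way.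

Compound 4 `Cc1n[nH]c2ccc(-c3nc4cnc(N5CCN(C)CC5)cn4c3Nc3cc(Cl)ccc3Cl)cc12` is not yet measured. Its change from compound 1 is 2,5-dichlorophenyl in place of 4-bromophenyl on a nitrogen on an aromatic ring. Going by the values given here, the step that bears on it is the one to compound 3, where a dichlorophenyl replaced the 4-bromophenyl and a number 4.2 percentage points lower from compound 1 to compound 3 (within the scatter); the dimethoxy step stands apart. A step within the scatter, or a modest loss, is therefore expected: a number 13 percentage points lower from compound 1 to compound 4 (beyond the scatter). Compound 4 is estimated at 70%, within 45% to 88%.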

Compound 4, a percentage reported as inhibition, at one concentration (the size of the read-out at that concentration, not a potency): 23.8%
Estimate against measurement, compound 4: 46.2 percentage points above, outside the stated range (below it).
By their numbers in this assay, from the lowest: compound 2; then compound 4; then compounds 3 and 1 (each within the scatter of the next).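

In this assay the two dichlorophenyl groups on this nitrogen are not interchangeable: a number 55 percentage points lower from compound 3 to compound 4 (beyond the scatter) shows that the substitution pattern on the ring matters, not merely the presence of two chlorines. The step of a number 59.2 percentage points lower from compound 1 to compound 4 (beyond the scatter) is also large, while a number 17.5 percentage points higher from compound 2 to compound 4 (beyond the scatter) leaves compound 4 above the 3,4-dimethoxyphenyl compound. Nothing available here gives a reason for this loss.

It remains open where a 2-chlorophenyl, a 3-chlorophenyl or an aminophenyl group on the same nitrogen would stand among these numbers.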